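From methyl to iodo on compound 2

The source may report more compounds than this note shows. Statements on the series, on what has been measured and on what is new or still open speak of the compounds shown alone.

Two related compounds have been measured in a functional assay on HT-29 cells (Homo sapiens) for antiproliferative activity, read by sulforhodamine B assay, with a stated time of 48 h; a lower number here means a stronger inhibitor, a higher number a weaker inhibitor. Compound 1 (`CN1CCN(c2ccc(S(=O)(=O)Oc3c(Cl)cc(Cl)cc3Cl)cc2)C1=O`) gives 2500 nM. Compound 2 (`Cc1cccc(OS(=O)(=O)c2ccc(N3CCN(C)C3=O)cc2)c1`) gives 4300 nM. These two values lie within the usual scatter of repeated measurements, so compound 2 stands level with compound 1 and the two cannot be ranked.

Compound 3 (`CN1CCN(c2ccc(S(=O)(=O)Oc3cccc(I)c3)cc2)C1=O`) has not yet been measured. It has iodo in place of methyl on an aromatic carbon of compound 2, so 3-methylphenyl becomes 3-iodophenyl: iodo in place of methyl on an aromatic carbon. Among the measured compounds shown here, no measured pair differs in just one place, so this swap has no direct precedent here.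

For the measured compounds named here, the only guide is that compound 1 at 2500 nM and compound 2 at 4300 nM differ in more than one place, yet remain within the scatter of each other. No step beyond the scatter is therefore expected in this assay. The estimated change is a 1.3-fold lower number from compound 2 to compound 3 (0.13 log units; within the scatter), which would stay within that scatter. For compound 3 the estimated value is 3200 nM, with an expected range of 1300 nM to 7500 nM.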

Compound 3, half-maximal inhibitory concentration: 590 nM
Compound 3: middle estimate off by 5.4-fold (0.73 log units), on the high side; the measured number lies below the stated range.
By their numbers in this assay, from the lowest: compound 3; then compounds 1 and 2 (each within the scatter of the next).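

In this assay, among the compounds shown here, replacing 3-methylphenyl with 3-iodophenyl gives a 7.3-fold lower number from compound 2 to compound 3 (0.86 log units; beyond the scatter) and is the first change here that can be read as a real difference rather than scatter. The position on this ring therefore matters for the read-out, and the identity of the single atom attached there is enough to shift the number. The swap exchanges one heavy atom for one heavy atom and changes neither the number of rings, hydrogen-bond donors or acceptors, nor the net charge, so these counts do not distinguish the two compounds, and nothing available here explains the gain.

From the compounds shown here alone, this is a single pair, so it remains open whether fluoro, chloro, bromo, methoxy or trifluoromethyl on the same aromatic carbon would give a number closer to that of compound 2 or of compound 3, which would show whether iodo is unusual or part of a wider trend. It is also unknown whether iodo on another carbon of the ring would produce a similar step, or whether the same swap would carry over to other cell lines.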